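Anilino variation on the shared core: forecast for compound 4

This account rests on a few compounds, and the source may have more. Where it says the series, first, only, none or still open, it means among the compounds named here.

Values in a functional assay on NCI-H1975 cells (Homo sapiens) for antiproliferative activity, read by MTT assay, with a stated time of 72 h; a lower number here means a stronger inhibitor, a higher number a weaker inhibitor:
- compound 1 `COc1cc2ncnc(Nc3ccc(Cl)c(C(F)(F)F)c3)c2cc1OCCCCC(=O)Nc1ccc(S(N)(=O)=O)cc1` gives 3220 nM
- compound 2 `C#Cc1cccc(Nc2ncnc3cc(OC)c(OCCCCC(=O)Nc4ccc(S(N)(=O)=O)cc4)cc23)c1` gives 18800 nM
- compound 3 `COc1ccc(Nc2ncnc3cc(OC)c(OCCCCC(=O)Nc4ccc(S(N)(=O)=O)cc4)cc23)cc1` gives 30200 nM

Compound 2 sits second highest of the three numbers in this assay; its nearest neighbour is compound 3, a step of a 1.6-fold higher number from compound 2 to compound 3 (0.21 log units; within the scatter), which is within the scatter, so no order between compound 2 and compound 3 is claimed. The furthest is compound 1, with a 5.8-fold higher number from compound 1 to compound 2 (0.77 log units; beyond the scatter) beyond the scatter.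

The step to compound 4 `COc1cc2ncnc(Nc3cc(F)c(F)c(F)c3)c2cc1OCCCCC(=O)Nc1ccc(S(N)(=O)=O)cc1` is 3,4,5-trifluorophenyl in place of 3-ethynylphenyl on a nitrogen on an aromatic ring. The measured steps that bear on it are those in which the group on the nitrogen is exchanged: a 5.8-fold higher number from compound 1 to compound 2 (0.77 log units; beyond the scatter) and a 9.4-fold higher number from compound 1 to compound 3 (0.97 log units; beyond the scatter). Both show that the halogen-bearing 4-chloro-3-(trifluoromethyl)phenyl of compound 1 gives the lowest number of the three, while 3-ethynylphenyl and 4-methoxyphenyl give higher numbers. Among the measured compounds shown here, the entering 3,4,5-trifluorophenyl is, like the group in compound 1, a halogen-bearing ring, but no compound with it has been measured, so the size of its effect is uncertain.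

A step of a 2.4-fold lower number from compound 2 to compound 4 (0.37 log units; beyond the scatter) is expected, that is a moderate move toward the value of compound 1. Compound 4 is therefore estimated at 8000 nM, with a range from 2500 nM to 25000 nM.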

Compound 4, half-maximal inhibitory concentration: 20000 nM
For compound 4 the middle estimate is 2.5-fold (0.40 log units) below the measured one, and the stated range covers the measured number.
By their numbers in this assay, from the lowest: compound 1; then compounds 2, 4 and 3 (each within the scatter of the next).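

In this assay, a halogen-bearing ring on this nitrogen does not by itself bring the number down towards that of compound 1: fluorine on the ring gives a 6.2-fold higher number from compound 1 to compound 4 (0.79 log units; beyond the scatter) and that step lies beyond the scatter, so compound 4 goes against any reading that links halogen substitution in general with the lower number. The exchange of 3-ethynylphenyl for 3,4,5-trifluorophenyl gives a 1.1-fold higher number from compound 2 to compound 4 (0.03 log units; within the scatter) and the exchange of 4-methoxyphenyl for the same ring gives a 1.5-fold lower number from compound 3 to compound 4 (0.18 log units; within the scatter) with both steps within the scatter, so these three groups cannot be told apart here, although their atoms differ, and compound 1 alone stands apart with the lowest number of the four. Nothing available on these compounds accounts for that separation.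

Going by these compounds, it remains open whether the lower number of compound 1 goes with the chlorine, with the trifluoromethyl or only with the two together, which a ring carrying either one alone would address. Also open, on these data alone, is whether a longer chain in the linker, or a carboxylic acid in place of the sulfonamide, would shift the numbers of this series.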